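Azido series: one stereocentre inverted

This account rests on a few compounds, and the source may have more. Where it says the series, first, only, none or still open, it means among the compounds named here.

Values in a functional assay on L1210 cells (Mus musculus) for antiproliferative activity, with a stated time of 72 h (on this read-out higher numbers stand for an effect only at larger amounts of compound and lower numbers for an effect already at smaller amounts), stand as follows:
- Compound 1 `Cc1cn([C@@H]2O[C@H](CO)[C@@H](CN=[N+]=[N-])[C@@H]2O)c(=O)[nH]c1=O` gives 10 uM as a number
- Compound 2 `Cc1cn([C@@H]2O[C@H](CO)[C@@H](CO)[C@@H]2O)c(=O)[nH]c1=O` gives > 100 uM as a limit
- Compound 3 `Cc1cn([C@@H]2O[C@H](CO)[C@@H](CN)[C@@H]2O)c(=O)[nH]c1=O` gives > 100 uM as a limit

For the measured compounds named here, compound 1 holds the only number here (the others sit at (the limit of > 100 uM in this assay, at which 2 of the 3 values shown sit)). Compound 4 `Cc1cn([C@@H]2O[C@H](CO)[C@@H](CN=[N+]=[N-])[C@H]2O)c(=O)[nH]c1=O` has the same atoms and bonds as compound 1, and the change is the two compounds have the same atoms and bonds; at least one stereo element is drawn with a configuration in one of them and without one in the other: 1 of 5 stereo elements differ; a stereocentre at a saturated ring carbon is drawn S in compound 1 and R in compound 4 in the shared core. Going by the values given here, no measured step touches a stereocentre. The nearest evidence is an at least 10-fold higher number from compound 1 to compound 2 (1.00 log units; beyond the scatter) and an at least 10-fold higher number from compound 1 to compound 3 (1.00 log units; beyond the scatter), both of which replace the azido group that compound 4 keeps. In this assay a modest rise is therefore expected and is loosely estimated to be a 3.0-fold higher number from compound 1 to compound 4 (0.48 log units; beyond the scatter). For compound 4 the estimated value is 30 uM (expected range 6 uM to 150 uM).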

Compound 4, concentration for half-maximal effect: > 100 uM
Compound 4: a limit, no number; the forecaster's own chance of this, stated with the estimate: 45%; at least 3.3-fold (0.52 log units) between middle value and limit.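

In this assay, keeping the azido group is not enough: with a stereocentre at a saturated ring carbon drawn R in place of S, and no atom or bond changed, the series shows an at least 10-fold higher number from compound 1 to compound 4 (1.00 log units; beyond the scatter). The earlier steps shown here all replaced the azido group, whereas this one shows that the configuration at this carbon also counts. Compound 4 gives > 100 uM, which is a limit.

Still open, on these data alone, is whether the other stereocentres are equally demanding. Also open, as far as these compounds go, is whether a nitrile or a longer azido-bearing chain at the azido position would give a number in this assay.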